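Bromo added to the dimethylamino analogue in the series

The source may hold more compounds than are shown below. What is called first, only, known or untested is meant among the compounds shown, and "the series" means these compounds.

Of the compounds shown here, two of the shared core have been measured. Compound 1 `COc1ccc(C2CC(c3ccccc3)=NN2C2=NC(=O)/C(=C3\C(=O)Nc4ccc(Br)cc43)S2)cc1` carries a methoxy and a bromo; in a functional assay on cells (Cancer cell lines, Homo sapiens) for cytotoxicity, read by sulforhodamine B assay, with a stated time of 48 h (on this read-out lower numbers stand for stronger inhibition of growth and higher numbers for weaker inhibition of growth), compound 1 gives 200 nM. Compound 2 `CN(C)c1ccc(C2CC(c3ccccc3)=NN2C2=NC(=O)/C(=C3\C(=O)Nc4ccccc43)S2)cc1` carries a dimethylamino and no bromo; in this assay compound 2 gives 5260 nM. Compound 2 thus stands at the highest of the two numbers, and its gap to compound 1 lies well beyond the scatter. The two compounds differ in two places, so no single-change step can be read from them.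

Compound 3 `CN(C)c1ccc(C2CC(c3ccccc3)=NN2C2=NC(=O)/C(=C3\C(=O)Nc4ccc(Br)cc43)S2)cc1` follows from compound 2 by bromo in place of hydrogen on an aromatic carbon. The bromo present in compound 1 200 nM sits on the same carbon, which points towards a lower number for compound 3, but the remaining difference between compound 1 and compound 2 is not resolved, so the size is uncertain. The step is expected to be a 3.5-fold lower number from compound 2 to compound 3 (0.54 log units; beyond the scatter), a clear move beyond the scatter towards stronger inhibition of growth. For compound 3 the estimate in this assay is 1500 nM, with a range from 400 nM to 6000 nM.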

Compound 3, concentration for 50% growth inhibition: 220 nM
The estimate for compound 3 lay 6.8-fold (0.83 log units) above the measured number; measured number outside the range, below it.
By their numbers in this assay, from the lowest: compounds 1 and 3 (each within the scatter of the next); then compound 2.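

In this assay, among these compounds, bromo in place of hydrogen on an aromatic carbon of the six-membered aromatic ring, part of a fused or bridged system of two rings, gives a 24-fold lower number from compound 2 to compound 3 (1.38 log units; beyond the scatter) as the first single-change reading at this position, and the step is large. With that bromo held constant, dimethylamino in place of methoxy on an aromatic carbon gives a 1.1-fold higher number from compound 1 to compound 3 (0.04 log units; within the scatter) and so does not separate the two bromo compounds in this assay, a reading available only now that compound 3 links them. No supporting measurement on hand bears on the origin of the bromo step.

The compounds shown leave open whether a bromo step of this size also holds with methoxy in place of dimethylamino, and whether the exchange of those two groups stays silent when hydrogen occupies the bromo position. They also leave open whether chloro, fluoro, a nitrile or an amine on this aromatic carbon would match bromo, so the result cannot yet be read as a general feature of substitution at this position.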